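The source may report more compounds than this note shows. Statements on the series, on what has been measured and on what is new or still open speak of the compounds shown alone.

Measured so far:
compound 1, `COc1cc(Cc2nc3c(N)ncnc3n2CCCCO)cc(OC)c1OC`, 76900000 nM
compound 2, `CCCCn1c(Cc2cc(OC)c(OC)c(OC)c2)nc2c(N)nc(F)nc21`, 185000000 nM

In a functional assay on MCF7 cells (Homo sapiens) for cytotoxicity (on this read-out higher numbers stand for an effect only at larger amounts of compound and lower numbers for an effect already at smaller amounts), compound 1 gives 76900000 nM and compound 2 gives 185000000 nM. Compound 2 thus holds the highest of the two numbers; its nearest neighbour is compound 1, and that gap lies beyond the scatter. Compound 3, `CCCCCn1c(Cc2cc(OC)c(OC)c(OC)c2)nc2c(N)nc(F)nc21`, is not yet measured. It differs from compound 2 by methyl in place of hydrogen on a saturated chain carbon, four bonds along the chain from an aromatic nitrogen. For the measured compounds named here, no step between two measured compounds shows what such a change does, so no direction can be read off; a step within the scatter is expected. Compound 3 is therefore estimated at 180000000 nM, range 60000000 nM to 550000000 nM. The expected step of a 1.0-fold lower number from compound 2 to compound 3 (0.01 log units; within the scatter) is taken to stay within the scatter.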

Compound 3, half-maximal effective concentration: 286000000 nM
For compound 3 the middle estimate is 1.6-fold (0.20 log units) below the measured one; the range from low to high includes it.
By their numbers in this assay, from the lowest: compound 1; then compounds 2 and 3 (each within the scatter of the next).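

In this assay, for the compounds shown here, methyl in place of hydrogen on a saturated chain carbon, four bonds along the chain from an aromatic nitrogen, gives a 1.5-fold higher number from compound 2 to compound 3 (0.19 log units; within the scatter) and is the first change that can be read at a single place. At this position, the added methyl therefore leaves the read-out within the scatter. No measured property bears on this result. From the compounds shown here alone, whether a longer chain, an amine or a carboxylic acid at this position would also stay within the scatter remains open. A single step shows no trend along the chain.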